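Chain shortening at the alkyl tail: compound 2 to compound 3

A few compounds are considered here, and "the series" means these few. Any claim that something is new, unique, unknown or untested is made for them only; others in the source may bear on it.

Compound 1 `CCCCCCCCCC[C@@H](O)[C@H](OS(=O)(=O)[O-])[C@H](O)C[S@+]1C[C@@H](O)[C@H](O)[C@H]1CO` is measured in an assay on intestine for inhibition of Maltase-glucoamylase (Homo sapiens) (a lower number here means a stronger inhibitor, a higher number a weaker inhibitor), at 1500 nM. Compound 2 `CCCCCCCC[C@@H](O)[C@H](OS(=O)(=O)[O-])[C@H](O)C[S@+]1C[C@@H](O)[C@H](O)[C@H]1CO`, which carries a shorter alkyl tail, gives 1200 nM in this assay. The step between them, a 1.3-fold lower number from compound 1 to compound 2 (0.10 log units; within the scatter), is not a change that the assay can resolve. Among the compounds with values here, on the numbers so far compound 2 holds the lowest value of the two, but its only neighbour, compound 1, sits within the scatter of it, so no order between the two can be claimed.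

Compound 3 `CCCCCC[C@@H](O)[C@H](OS(=O)(=O)[O-])[C@H](O)C[S@+]1C[C@@H](O)[C@H](O)[C@H]1CO` continues the same cut: hydrogen in place of ethyl on a saturated chain carbon, seven bonds along the chain from an oxygen on a saturated carbon. Within the data shown here, the one step that bears on this is the earlier shortening, a 1.3-fold lower number from compound 1 to compound 2 (0.10 log units; within the scatter), which stayed within the scatter. A further removal of the same kind is therefore expected to move this assay little if at all, with the expected step from compound 2 to compound 3 being a 1.2-fold higher number from compound 2 to compound 3 (0.07 log units; within the scatter). Among the measured compounds shown here, the estimate for compound 3 in this assay is 1400 nM, with a range from 600 nM to 4000 nM; the range is kept wide because only a single step, a 1.3-fold lower number from compound 1 to compound 2 (0.10 log units; within the scatter), informs it.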

Compound 3, half-maximal inhibitory concentration: 1700 nM
Estimate against measurement, compound 3: 1.2-fold (0.08 log units) below; the measured number falls inside the stated range.
By their numbers in this assay, from the lowest: compounds 2, 1 and 3 (each within the scatter of the next).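

Cutting a further ethyl to hydrogen, on a saturated chain carbon seven bonds along the chain from an oxygen on a saturated carbon, gives no resolvable change in this assay (a 1.4-fold higher number from compound 2 to compound 3 (0.15 log units; within the scatter)). The full cut, hydrogen in place of butyl at that same place, is no more visible (a 1.1-fold higher number from compound 1 to compound 3 (0.05 log units; within the scatter)), so the flat reading now covers two successive ethyl removals and the larger combined removal, and compound 1, compound 2 and compound 3 cannot be put in any order on this read-out. No measurement is available that offers an explanation for this flat stretch of the tail.

Still open, on these data alone, is whether the flat stretch continues once the tail is cut further or extended, for example to a propyl or methyl tail or to a longer chain than that of compound 1. Also open, as far as these compounds go, is whether a tail ending in a carboxylic acid or an amine, rather than plain alkyl, would move the number in this assay beyond the scatter.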